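Swapping a Cyanophenyl for a Trimethoxyphenyl on a Shared Core

This account rests on a few compounds, and the source may have more. Where it says the series, first, only, none or still open, it means among the compounds named here.

Two measured compounds share one core and differ only in the aromatic group carried on a nitrogen of that core. Compound 1 `CN(c1ncccc1CNc1nc(Nc2ccc(F)c(Cl)c2)nc2[nH]cc(F)c12)S(C)(=O)=O` carries a 3-chloro-4-fluorophenyl there, and in a functional assay on SMMC-7721 cells (Homo sapiens) for inhibition, read by MTT assay, with a stated time of 48 h (on this read-out higher numbers stand for weaker inhibition and lower numbers for stronger inhibition), compound 1 gives only a limit of the assay, > 100000 nM. Compound 2 `CN(c1ncccc1CNc1nc(Nc2cccc(C#N)c2)nc2[nH]cc(F)c12)S(C)(=O)=O` carries a 3-cyanophenyl instead, and in this assay compound 2 likewise gives only a limit, > 100000 nM. The step that the two limits leave unreadable from compound 1 to compound 2 therefore cannot be read, and both results sit at the limit of > 100000 nM in this assay, at which 2 of the 2 values shown sit. The next compound, compound 3 `COc1cc(Nc2nc(NCc3cccnc3N(C)S(C)(=O)=O)c3c(F)c[nH]c3n2)cc(OC)c1OC`, differs from compound 2 by 3,4,5-trimethoxyphenyl in place of 3-cyanophenyl on a nitrogen on an aromatic ring. Among the measured compounds shown here, no measured step bears on this change with a readable size; the one comparison available shows two limits and nothing more. The two measured compounds show no measurable inhibition at all. Compound 3 is therefore expected to show a step of a number no higher from compound 2 to compound 3 (the limit leaves the size open) that most likely ends at a limit again rather than at a number. Compound 3 is estimated at 100000 nM, with a range from 30000 nM to 300000 nM.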

Compound 3, half-maximal inhibitory concentration: > 100000 nM
Compound 3: only a limit was reported (the forecaster's own chance of this, stated with the estimate: 70%); the middle value lies on the limit itself.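

Compound 3 ends at a limit of the assay rather than at a number, so no size can be read for any step among compound 1, compound 2 and compound 3: the limit of > 100000 nM in this assay, at which 3 of the 3 values shown sit. The compounds shown leave open where their true values lie, and whether exchanging these aromatic groups on that nitrogen changes inhibition at all in this assay.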